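An Oxadiazole Isomer Replaces the Oxetanyl Carbamate

The compounds below may be only part of what the source reports. "The series", "measured", "known", "first", "only" and "open" are said of these compounds alone.

Compound 1 `Cc1nc(S(C)(=O)=O)ccc1Oc1ncnc(OC2CCN(C(=O)OC3COC3)CC2)c1F` gives 326 nM in a functional assay on isolated protein for inhibition of Glucose-dependent insulinotropic receptor (Homo sapiens), read by HTRF and cAMP accumulation (a higher number here means that more compound is needed for the effect, a lower number that less compound is needed), the highest of the three numbers shown. Compound 2 `Cc1nc(S(C)(=O)=O)ccc1Oc1ncnc(OC2CCN(C(=O)SC3(C)CC3)CC2)c1F` gives 13.2 nM in this assay, and compound 3 `Cc1nc(S(C)(=O)=O)ccc1Oc1ncnc(OC2CCN(C(=O)c3noc(C(C)(C)F)n3)CC2)c1F` gives 14 nM. Compound 4 `Cc1nc(S(C)(=O)=O)ccc1Oc1ncnc(OC2CCN(C(=O)c3nc(C(C)(C)F)no3)CC2)c1F` differs from compound 1 in this way: a group of 9 heavy atoms (5 carbon, 2 nitrogen, 1 oxygen, 1 fluorine; one five-membered aromatic ring with 3 hetero atoms) in place of a group of 5 heavy atoms (3 carbon, 2 oxygen; one four-membered non-aromatic ring with 1 hetero atom), on a carbonyl carbon. Among the compounds with values here, two measured steps bear directly on this change, a 25-fold lower number from compound 1 to compound 2 (1.39 log units; beyond the scatter) and a 23-fold lower number from compound 1 to compound 3 (1.37 log units; beyond the scatter), both large and in the same direction. Within the data shown here, the group entering in compound 4 has the same composition as the one in compound 3, arranged differently within the five-membered aromatic ring with 3 hetero atoms. Compound 4 is therefore expected to show a large drop, an 18-fold lower number from compound 1 to compound 4 (1.26 log units; beyond the scatter), with an estimated value of 18 nM and a range from 6 nM to 60 nM.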

Compound 4, half-maximal effective concentration: 43.4 nM
Estimate against measurement, compound 4: 2.4-fold (0.38 log units) below, and the stated range covers the measured number.
By their numbers in this assay, from the lowest: compounds 2 and 3 (each within the scatter of the next); then compound 4; then compound 1.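

Rearranging the same atoms within the five-membered aromatic ring on the carbonyl carbon matters: a 3.1-fold higher number from compound 3 to compound 4 (0.49 log units; beyond the scatter) in this assay, although the composition of the group is unchanged. The gain over the (oxetan-3-yl)oxy group survives in this isomer but is smaller, at a 7.5-fold lower number from compound 1 to compound 4 (0.88 log units; beyond the scatter), and the isomer also falls short of the sulfur-containing group, with a 3.3-fold higher number from compound 2 to compound 4 (0.52 log units; beyond the scatter). No available evidence accounts for the difference between the two ring arrangements. On these data alone, whether that difference persists when a tert-butyl group replaces the fluorinated substituent on the ring remains open.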